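The compounds below may be only part of what the source reports. "The series", "measured", "known", "first", "only" and "open" are said of these compounds alone.

Measured in an ADME assay (liver) for metabolic stability, with Liver microsome (Rattus norvegicus) as the target, using microsomes, with a stated time of 30 min, tested at 1 uM; on this read-out lower numbers stand for slow clearance and higher numbers for fast clearance:
- Compound 1 `O=C(CCSc1nc2ccccc2c(=O)[nH]1)N[C@H]1CC[C@H](c2nnc(-c3ccccc3)o2)CC1`: 57 mL.min-1.g-1
- Compound 2 `O=C(CCSc1nc2c(c(=O)[nH]1)CCCC2)N[C@H]1CC[C@H](c2nnc(-c3ccccc3)o2)CC1`: 60 mL.min-1.g-1
- Compound 3 `O=C(C[C@H]1CCCN1Cc1nc2ccccc2c(=O)[nH]1)N[C@H]1CC[C@H](c2nnc(-c3ccccc3)o2)CC1`: > 399 mL.min-1.g-1 (a limit of the assay, not a number)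

Compound 2, at 60 mL.min-1.g-1, lies within the scatter of compound 1, at 57 mL.min-1.g-1. Compound 4 `O=C(CCSc1nccc(=O)[nH]1)N[C@H]1CC[C@H](c2nnc(-c3ccccc3)o2)CC1` differs from compound 2 by a group of 7 heavy atoms (4 carbon, 2 nitrogen, 1 oxygen; one six-membered aromatic ring with 2 hetero atoms) in place of a group of 11 heavy atoms (8 carbon, 2 nitrogen, 1 oxygen; one six-membered non-aromatic ring of carbon only, one six-membered aromatic ring with 2 hetero atoms), on a sulfur. The six-membered non-aromatic ring of carbon only is lost, on a sulfur whose other neighbours are: saturated chain carbon.

Among the measured compounds shown here, the one measured step at this sulfur, a 1.1-fold higher number from compound 1 to compound 2 (0.02 log units; within the scatter), exchanged a group of the same size and stayed within the scatter. No step beyond the scatter is therefore expected in this assay, though this rests on a single step. The expected change is a 1.3-fold lower number from compound 2 to compound 4 (0.10 log units; within the scatter). Compound 4 is estimated at 48 mL.min-1.g-1, with an expected range of 22 mL.min-1.g-1 to 105 mL.min-1.g-1.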

Compound 4, intrinsic clearance in microsomes: < 14 mL.min-1.g-1
Compound 4 ended at the assay's limit; the forecaster's own chance of this, stated with the estimate: 3%; middle value at least 3.4-fold (0.53 log units) away from the limit.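

In this assay, removing a ring from the group on this sulfur moved the number, which exchanging one ring for another had not done. Loss of the six-membered non-aromatic ring of carbon only gives an at least 4.2-fold lower number from compound 2 to compound 4 (0.63 log units; beyond the scatter), and loss of the six-membered aromatic ring of carbon only gives an at least 4.0-fold lower number from compound 1 to compound 4 (0.60 log units; beyond the scatter), both beyond the scatter. Compound 4 stands at a limit of the assay, not at a number, so the full size of neither step is known: the limit of < 14 mL.min-1.g-1 in this assay, at which 1 of the 4 values shown sits.

The compounds shown leave open whether an amine or a carboxylic acid in place of the lost ring would give the same low reading in this assay.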